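A few compounds are considered here, and "the series" means these few. Any claim that something is new, unique, unknown or untested is made for them only; others in the source may bear on it.

In an ADME assay on L02 cells (Homo sapiens) for cytotoxicity, read by MTT assay (a lower number here means a stronger inhibitor, a higher number a weaker inhibitor), compound 1 `C=CCOc1cc(/C=C/C(=O)c2ccc(OC)c3c2OC(C)(C)C=C3)ccc1OC` gives > 20000 nM and that is a limit only. Compound 2 `C=CC(=O)Oc1cc(/C=C/C(=O)c2ccc(OC)c3c2OC(C)(C)C=C3)ccc1OC` gives > 10000 nM and that too is a limit only. Within the data shown here, compound 3 `COc1ccc(/C=C/C(=O)Oc2cc(/C=C/C(=O)c3ccc(OC)c4c3OC(C)(C)C=C4)ccc2OC)cc1` gives 18000 nM as the only true number among the three.

Compound 4 `COc1ccc(/C=C/C(=O)c2ccc(OC)c3c2OC(C)(C)C=C3)cc1OC(=O)c1ccco1` differs from it by the change furan-2-yl in place of 2-(4-methoxyphenyl)ethenyl on a carbonyl carbon with furan-2-yl in place of 2-(4-methoxyphenyl)ethenyl on a carbonyl carbon. Among the measured compounds shown here, the one measured change at that carbonyl carbon is a step that the limit leaves unreadable from compound 2 to compound 3 and it offers no size to carry over. The same holds for a step that the two limits leave unreadable from compound 1 to compound 2 at the oxygen on an aromatic ring. The remaining step is an at least 1.1-fold lower number from compound 1 to compound 3 (0.04 log units; that floor lies within the scatter) and its floor does not clear the scatter.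

For the measured compounds named here, no measured step therefore points in either direction in this assay and no shift beyond the scatter is expected. The estimated step is a 1.1-fold higher number from compound 3 to compound 4 (0.05 log units; within the scatter). A limit in place of a true number would be unsurprising. The range expected for compound 4 runs from 9000 nM to 45000 nM around an estimate of 20000 nM as a working figure.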

Compound 4, half-maximal inhibitory concentration: > 10000 nM
Compound 4: only a limit was reported; the forecaster's own chance of this, stated with the estimate: 50%; the middle value does not contradict the limit.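

In this assay compound 4 gives > 10000 nM, which is a limit only. Among these compounds, no step from compound 1, compound 2 or compound 3 to compound 4 can be read. The compounds shown leave open how far furan-2-yl in place of 2-(4-methoxyphenyl)ethenyl on a carbonyl carbon moves the number in this assay.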